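Trimming One Methoxy on the Carbonyl-Side Ring of Compound 2

The source may report more compounds than this note shows. Statements on the series, on what has been measured and on what is new or still open speak of the compounds shown alone.

The two measured compounds share a core and differ only in the group on the carbonyl carbon. Compound 1 `COc1cc(-c2cc(/C=C/C(=O)c3ccc(N)cc3)[nH]n2)cc(OC)c1OC` gives in a functional assay on SK-MEL-2 cells (Homo sapiens) for cytotoxicity, read by sulforhodamine B assay, with a stated time of 48 h, tested at 100 uM (a higher number here means a weaker effect of the compound at the concentration tested, a lower number a stronger effect), a value of -85%. Going by the values given here, compound 2 `COc1ccc(C(=O)/C=C/c2cc(-c3cc(OC)c(OC)c(OC)c3)n[nH]2)cc1OC` gives in this assay a value of -96%, the lower of the two numbers; the single measured step, a number 11 percentage points lower from compound 1 to compound 2 (beyond the scatter), is modest though beyond the scatter. Compound 3 `COc1ccc(C(=O)/C=C/c2cc(-c3cc(OC)c(OC)c(OC)c3)n[nH]2)cc1` differs from compound 2 by hydrogen in place of methoxy on an aromatic carbon. Among the compounds with values here, no measured step removes a methoxy. Within the data shown here, the only step that touches this ring, a number 11 percentage points lower from compound 1 to compound 2 (beyond the scatter), exchanged the whole group and shifted the number only modestly, so a change at one position of that ring is expected to move it little, at most slightly towards a higher number and possibly not beyond the scatter. Compound 3 is therefore estimated at -90%, between -100% and -72%. The step expected is a number 6 percentage points higher from compound 2 to compound 3 (within the scatter).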

Compound 3, a percentage reported as activity, at one concentration (the size of the read-out at that concentration, not a potency): -50%
Compound 3: middle estimate off by 40 percentage points, on the low side, outside the stated range (above it).
By their numbers in this assay, from the lowest: compound 2; then compound 1; then compound 3.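

In this assay, removing one methoxy proves to be no small change: hydrogen in place of methoxy on this aromatic carbon, which turns 3,4-dimethoxyphenyl into 4-methoxyphenyl, gives a number 46 percentage points higher from compound 2 to compound 3 (beyond the scatter) and is a large step. The earlier exchange of the whole group had not revealed this dependence on a single methoxy, and the 4-methoxyphenyl group also differs clearly from the 4-aminophenyl group, with methoxy in place of amino giving a number 35 percentage points higher from compound 1 to compound 3 (beyond the scatter) as a second large step. Nothing available accounts for the size of either step.

The compounds shown leave open whether a hydroxyl group or a chlorine atom at the vacated position would restore the lower number of compound 2. They also leave open how much the remaining methoxy on this ring contributes.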